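Swapping phenyl for pyrrolyl on a benzylidene thiazolone

The source may hold more compounds than are shown below. What is called first, only, known or untested is meant among the compounds shown, and "the series" means these compounds.

Measured so far:
Compound 1, `CCOC(=O)C1=C(Nc2ccccc2)S/C(=C\c2ccccc2)C1=O`: 29.6%
Compound 2, `CCOC(=O)C1=C(Nc2ccccc2)S/C(=C\c2ccccc2C(F)(F)F)C1=O`: < 10%

Compound 1 is the reference point here. Going by the values given here, in a functional assay on A549 cells (Homo sapiens) for inhibition, read by MTT assay, with a stated time of 72 h, tested at 10 uM (on this read-out lower numbers stand for less inhibition and higher numbers for more inhibition at the one concentration tested (going by the name of the read-out)), compound 1 gives 29.6%, the only plain number among the two values shown. For compound 2 the assay reports only a limit, < 10%, not a number. Among the compounds with values here, the step of a number at least 19.6 percentage points lower from compound 1 to compound 2 (beyond the scatter) is the one measured change available, and it runs in the direction of less inhibition.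

Compound 3, `CCOC(=O)C1=C(Nc2ccccc2)S/C(=C\c2cc[nH]c2)C1=O`, has not yet been measured. It differs from compound 1 in one place: 1H-pyrrol-3-yl in place of phenyl on a double-bonded chain carbon bound to a double-bonded ring carbon. Within the data shown here, no measured step involves this change, so the step to compound 2 bears on it only indirectly, as a sign that altering the ring on that chain carbon can push the read-out down to the limit (the limit of < 10% in this assay, at which 1 of the 2 values shown sits). Compound 3 is therefore expected to sit near or somewhat under compound 1, with the step of a number 7.6 percentage points lower from compound 1 to compound 3 (within the scatter) as the expected outcome. The estimate for compound 3 in this assay is 22%, expected to fall between 5% and 40%.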

Compound 3, a percentage reported as inhibition, at one concentration (the size of the read-out at that concentration, not a potency): < 10%
Compound 3: a limit, no number; the forecaster's own chance of this, stated with the estimate: 30%; middle value at least 12 percentage points away from the limit.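

Going by these compounds alone, until now, the only measured change on this chain carbon kept the phenyl and added a trifluoromethyl to it. Here the whole ring is exchanged, and in this assay 1H-pyrrol-3-yl in place of phenyl gives a number at least 19.6 percentage points lower from compound 1 to compound 3 (beyond the scatter), so a change of the ring itself also removes most of the modest inhibition seen with the phenyl. As far as these compounds go, compound 3 gives < 10%, which is a limit and not a number, so the full size of the step stays unknown. Among the compounds shown, only the unsubstituted phenyl of compound 1 gives a plain number, and the two altered compounds cannot be ranked against each other: the limit of < 10% in this assay, at which 2 of the 3 values shown sit.

From the compounds shown here alone, what stays open is whether any other ring on this chain carbon, such as a pyridine or a thiophene, or a phenyl carrying a methoxy group or an amine, would keep or raise the inhibition. Going by these compounds, whether the hydrogen on the pyrrole nitrogen plays any part is also open, and a 1-methylpyrrol-3-yl group would be the closest comparison for that question.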